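Series notes: methyl in place of 4-chlorophenyl

The compounds below may be only part of what the source reports. "The series", "measured", "known", "first", "only" and "open" are said of these compounds alone.

Two compounds of the series have been run in a functional assay on the whole organism for inhibition, with Mus musculus as the target, with a stated time of 2 h, at a dose of 50 mg/kg by the oral route; on this read-out lower numbers stand for less inhibition and higher numbers for more inhibition at the one dose given (going by the name of the read-out). Compound 1 `Cc1ccc(-c2c(S(=O)(=O)c3ccccc3)cnc3cc(C)nn23)cc1` gives 25.2% in this assay. Compound 2 `O=S(=O)(c1ccccc1)c1cnc2cc(-c3ccc(Cl)cc3)nn2c1-c1ccc(Br)cc1` gives 24.7% in this assay. Compound 2 sits within the scatter of compound 1; the two numbers read as one level, and no order between them can be claimed. For the measured compounds named here, no pair of measured compounds differs in a single place, so no measured step is available from which the effect of a single change could be read.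

Compound 3 `Cc1cc2ncc(S(=O)(=O)c3ccccc3)c(-c3ccc(Br)cc3)n2n1` has not been measured. It differs from compound 2 in one place: methyl in place of 4-chlorophenyl on an aromatic carbon. Going by the values given here, the one precedent of use is compound 1, which also carries a methyl rather than an aryl group at that place and gives 25.2% in this assay. The expected step in this assay from compound 2 to compound 3 is therefore a number 0.3 percentage points higher from compound 2 to compound 3 (within the scatter), a change not beyond the scatter and in no settled direction. Compound 3 is expected to give about 25% in this assay, with a range from 10% to 40%, because compound 1 gives 25.2% with a methyl at the same place.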

Compound 3, a percentage reported as inhibition, in the whole organism at one dose (the size of the read-out at that dose, not a potency): 5.2%
For compound 3 the middle estimate is 19.8 percentage points above the measured one; measured number outside the range, below it.
By their numbers in this assay, from the lowest: compound 3; then compounds 2 and 1 (each within the scatter of the next).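

In this assay, for the compounds shown here, the 4-chlorophenyl on the five-membered aromatic ring with 2 nitrogen cannot be exchanged freely for methyl while the bromo group stays in place: this change gives a number 19.5 percentage points lower from compound 2 to compound 3 (beyond the scatter) and shows that the place matters in this setting, which the earlier compounds, with no single-place step among them, could not show. With the methyl held at that place, bromo in place of methyl on an aromatic carbon gives a number 20 percentage points lower from compound 1 to compound 3 (beyond the scatter) and so shows that a methyl at the first place does not set the level by itself, since the outcome also follows the group at the second place. No measurement at hand gives a reason for either step.

Still open, on these data alone, is whether a plain phenyl, an ethyl chain or an amine at the first place would hold the level of compound 2 or stay with compound 3. Also open is whether the gaps among these compounds persist at other oral doses or other times in this assay, as only one dose and one time are shown.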